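Loss of the 1,3-benzothiazol-2-yl group from compound 2

This account rests on a few compounds, and the source may have more. Where it says the series, first, only, none or still open, it means among the compounds named here.

Measured in an ADME assay on HEK293 cells (Homo sapiens) for cytotoxicity, with a stated time of 72 h; on this read-out higher numbers stand for an effect only at larger amounts of compound and lower numbers for an effect already at smaller amounts:
- Compound 1 `O=C(Nc1cccc(-c2nc3ccccc3s2)c1)c1cc([N+](=O)[O-])ccc1Cl`: > 27000 nM, a limit
- Compound 2 `O=C(Nc1ccc(Cl)c(-c2nc3ccccc3s2)c1)c1cc([N+](=O)[O-])ccc1Cl`: > 25000 nM, a limit

Compound 2 has no number on this read-out, only the limit of > 25000 nM. The next compound, compound 3 `O=C(Nc1ccc(Cl)cc1)c1cc([N+](=O)[O-])ccc1Cl`, differs from it as follows: hydrogen in place of 1,3-benzothiazol-2-yl on an aromatic carbon. Going by the values given here, the one measured step, a step that the two limits leave unreadable from compound 1 to compound 2, is chloro in place of hydrogen on an aromatic carbon. That is a different change, and it offers no size to carry over. The expectation therefore rests on compound 2 at > 25000 nM, which is a limit. No direction can be argued from these data, and a further limit is likely. The expected move is a step that the limit leaves unreadable from compound 2 to compound 3, with nothing expected beyond the scatter in this assay. For compound 3 the estimate is 35000 nM, with an expected range of 12000 nM to 45000 nM.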

Compound 3, half-maximal effective concentration: > 27000 nM
Compound 3: only a limit was reported (the forecaster's own chance of this, stated with the estimate: 75%); the middle value does not contradict the limit.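

In this assay, compound 2 and compound 3 are both reported only as limits, and the step between them cannot be read. With compound 1 also a limit, the compounds shown leave open whether removing the 1,3-benzothiazol-2-yl group shifts this read-out at all.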